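Working notes: 4-hydroxyphenyl in place of 2,3,4-trimethoxyphenyl

A few compounds are considered here, and "the series" means these few. Any claim that something is new, unique, unknown or untested is made for them only; others in the source may bear on it.

Measured so far in a functional assay on PC-3 cells (Homo sapiens) for cytotoxicity, read by MTT assay, with a stated time of 72 h; a lower number here means a stronger inhibitor, a higher number a weaker inhibitor:
- compound 1 `COc1cc2ncnc(Nc3ccc(F)c(Cl)c3)c2cc1NC(=O)N/N=C/c1cccc(Cl)c1Cl` gives 24400 nM
- compound 2 `COc1cc2ncnc(Nc3ccc(F)c(Cl)c3)c2cc1NC(=O)N/N=C/c1ccc(OC)c(OC)c1OC` gives 29300 nM

Only these two numbers exist, and they do not separate. Among the compounds with values here, the single measured step is a 1.2-fold higher number from compound 1 to compound 2 (0.08 log units; within the scatter). Within the data shown here, compound 2 thus stands level with the only other measured compound, and both share the same core.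

The next compound is compound 3 `COc1cc2ncnc(Nc3ccc(F)c(Cl)c3)c2cc1NC(=O)N/N=C/c1ccc(O)cc1`, with 4-hydroxyphenyl in place of 2,3,4-trimethoxyphenyl on a carbon with a double bond to nitrogen.

Among the measured compounds shown here, the one measured step changes the same place, and it is the only guide here. Going from 2,3-dichlorophenyl to 2,3,4-trimethoxyphenyl left this assay within the scatter, as a 1.2-fold higher number from compound 1 to compound 2 (0.08 log units; within the scatter) shows. On that basis, no step beyond the scatter is expected, and no direction can be favoured. Neither measured compound carries a hydroxy group on this ring, so the new group lies outside what has been tested and the range is kept wide.

The expected step is a 1.2-fold lower number from compound 2 to compound 3 (0.07 log units; within the scatter). For compound 3 the estimated value is 25000 nM, with an expected range from 10000 nM to 60000 nM.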

Compound 3, half-maximal inhibitory concentration: 16600 nM
For compound 3 the middle estimate is 1.5-fold (0.18 log units) above the measured one; measured number inside the range.
By their numbers in this assay, from the lowest: compounds 3, 1 and 2 (each within the scatter of the next).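

In this assay, 4-hydroxyphenyl in place of 2,3,4-trimethoxyphenyl on a carbon with a double bond to nitrogen gives a 1.8-fold lower number from compound 2 to compound 3 (0.25 log units; within the scatter) and, in place of 2,3-dichlorophenyl, gives a 1.5-fold lower number from compound 1 to compound 3 (0.17 log units; within the scatter) so all three groups at this place remain level. The level readout now extends to a group with 1 hydrogen-bond donor and 7 heavy atoms, against the 2,3,4-trimethoxyphenyl group with 0 hydrogen-bond donors and 12 heavy atoms, and neither difference separates compound 3 from compound 2 in this readout. No independent measurement is available to account for these numbers.

As far as these compounds go, all three groups at this place are substituted phenyl rings, so it remains open whether an amine, a carboxylic acid or a longer alkyl chain on this carbon would give a step beyond the scatter. The shared core is the same in compound 1, compound 2 and compound 3, which leaves open how changes elsewhere in the molecule, such as replacing the methoxy group on the core with a longer alkoxy chain, would read in this assay and whether any of them would separate from this group of compounds.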